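Two limits and a trifluoromethyl swap

This account rests on a few compounds, and the source may have more. Where it says the series, first, only, none or still open, it means among the compounds named here.

Measured in a functional assay on G-361 cells (Homo sapiens) for antiproliferative activity, with a stated time of 72 h; on this read-out higher numbers stand for weaker inhibition and lower numbers for stronger inhibition:
- compound 1 `Cc1ccc(CNc2ncnc3c2ncn3[C@@H]2O[C@H](CO)[C@@H](O)[C@H]2O)cc1` gives "not determined" (no result reported) (no result reported)
- compound 2 `COc1ccccc1CNc1ncnc2c1ncn2[C@@H]1O[C@H](CO)[C@@H](O)[C@H]1O` gives > 166000 nM (a limit of the assay)
- compound 3 `OC[C@H]1O[C@@H](n2cnc3c(NCc4ccc(F)c(Cl)c4)ncnc32)[C@H](O)[C@@H]1O` gives > 166000 nM (a limit of the assay)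

Compound 3 has no exact number to start from. In this assay compound 3 gives > 166000 nM and this is a limit, not a measured value. The wider picture is the limit of > 166000 nM in this assay, at which 2 of the 3 values shown sit, and compound 1 adds no result to it.

Compound 4 `OC[C@H]1O[C@@H](n2cnc3c(NCc4cccc(C(F)(F)F)c4)ncnc32)[C@H](O)[C@@H]1O` keeps the shared core of compound 3 and carries 3-(trifluoromethyl)phenyl in place of 3-chloro-4-fluorophenyl on a saturated chain carbon bound to a nitrogen on an aromatic ring. The count of what changes is 3-(trifluoromethyl)phenyl in place of 3-chloro-4-fluorophenyl on a saturated chain carbon bound to a nitrogen on an aromatic ring and the ring type stays the same.

Among the measured compounds shown here, one measured step bears on this change, as it falls at the same place. It is a step that the two limits leave unreadable from compound 2 to compound 3 and so it offers no size to carry over. For the measured compounds named here, with the limit of > 166000 nM in this assay, at which 2 of the 3 values shown sit, as the only guide, no step beyond the usual scatter is expected in this assay and no direction can be favoured. The expected step is a number no higher from compound 3 to compound 4 (the limit leaves the size open) as an estimate only. For compound 4 the estimated value is 166000 nM with an expected range from 50000 nM to 330000 nM and a limit of the assay is the likeliest expected outcome.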

Compound 4, half-maximal inhibitory concentration: > 166000 nM
Compound 4 was reported as a limit; the forecaster's own chance of this, stated with the estimate: 75%; the middle value lies on the limit itself.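

In this assay compound 4 gives > 166000 nM, which is a limit of the assay. The steps among compound 2, compound 3 and compound 4 cannot be read, as all three results are limits. The compounds shown leave open how these three truly compare, and whether any group at this place gives a measurable value.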